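The source may report more compounds than this note shows. Statements on the series, on what has been measured and on what is new or still open speak of the compounds shown alone.

Of the compounds shown here, three from this set have been measured in a functional assay on MDA-MB-231 cells (Homo sapiens) for cytotoxicity; a lower number here means a stronger inhibitor, a higher number a weaker inhibitor. Compound 1 (`COc1ccc(Cn2cc(/C=N\NC(=O)c3c[nH]c4ccccc34)c3ccccc32)cc1`) gives 15100 nM in this assay. Compound 2 (`COc1ccc(Cn2cc(/C=N\NC(=O)c3c[nH]c4ccccc34)c3cc(OC)ccc32)cc1`) carries an added methoxy on the shared core and gives 9800 nM in this assay; the step of a 1.5-fold lower number from compound 1 to compound 2 (0.19 log units; within the scatter) is too small to count as a real change. Compound 3 (`COc1ccc2c(c1)c(/C=N\NC(=O)c1cn(C)c3ccccc13)cn2Cc1ccc(Cl)cc1`), which has a methyl on the indole nitrogen and a chlorobenzyl group, gives > 100000 nM in this assay, and that is a limit of the assay rather than a number (the limit of > 100000 nM in this assay, at which 1 of the 3 values shown sits). Among the two numbers actually recorded, compound 2 sits at the lower end, though its only neighbour is compound 1 within the scatter.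

Compound 4 (`COc1ccc2c(c1)c(/C=N\NC(=O)c1c[nH]c3ccccc13)cn2Cc1ccc(Cl)cc1`) has not yet been measured. It differs from compound 2 by chloro in place of methoxy on an aromatic carbon. Among the measured compounds shown here, no measured step changes this position alone: the only step recorded, from compound 1 to compound 2, concerns the methoxy on the core, and compound 3 differs from compound 4 in a second place as well. Without a comparable step to lean on, the expectation for compound 4 is a number near that of compound 2, so the step of a 1.5-fold higher number from compound 2 to compound 4 (0.18 log units; within the scatter) is estimated to stay within the scatter. Compound 4 is therefore expected to give about 15000 nM in this assay, with a likely range from 4000 nM to 60000 nM.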

Compound 4, half-maximal inhibitory concentration: 82700 nM
The estimate for compound 4 lay 5.5-fold (0.74 log units) below the measured number, and the stated range ends below it.
By their numbers in this assay, from the lowest: compounds 2 and 1 (each within the scatter of the next); then compound 4. At a limit, above all of these: compound 3.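

Among the compounds shown here, the 4-methoxybenzyl to 4-chlorobenzyl change brings an 8.4-fold higher number from compound 2 to compound 4 (0.93 log units; beyond the scatter), and this shift lies beyond the scatter, unlike the only earlier step, where a methoxy added on the shared core stayed within it. In this assay, for the compounds shown here, the group on this aromatic carbon, para to a large group, therefore matters more than the earlier compounds could show, and among the pairs that can be compared, chloro in place of methoxy here goes with the higher number. Compound 3 stands at a limit and not a number, so hydrogen in place of methyl on the aromatic nitrogen can be read only as an at least 1.2-fold lower number from compound 3 to compound 4 (0.08 log units; that floor lies within the scatter), a floor that cannot give the true size of that change: the limit of > 100000 nM in this assay, at which 1 of the 4 values shown sits.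

As far as these compounds go, only methoxy and chloro appear at this position, so it stays open whether other groups there, such as an amine or a carboxylic acid, would give a number closer to that of compound 2 or to that of compound 4. Going by these compounds alone, also open is what the methyl on the aromatic nitrogen does on its own, as the one pair that shows it ends at a limit.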